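Lengthening the alkyl chain on the aryl of compound 3

A few compounds are considered here, and "the series" means these few. Any claim that something is new, unique, unknown or untested is made for them only; others in the source may bear on it.

Of the compounds shown here, three have been tested in a functional assay on HeLa cells (Homo sapiens) for inhibition, read by MTT assay, with a stated time of 72 h; a higher number here means a weaker inhibitor, a lower number a stronger inhibitor. Compound 1 `O=c1cc(Cn2cc(CCO)nn2)c2ccc(O)cc2o1` reaches only a limit in this assay, > 100000 nM. Compound 2 `CC(O)c1cn(Cc2cc(=O)oc3cc(O)ccc23)nn1` likewise reaches only a limit in this assay, > 100000 nM. The change a step that the two limits leave unreadable from compound 1 to compound 2 therefore cannot be sized, since both ends sit at the limit of > 100000 nM in this assay, at which 2 of the 3 values shown sit. For the measured compounds named here, compound 3 `CCCCc1ccc(-c2cn(Cc3cc(=O)oc4cc(O)ccc34)nn2)cc1` is the single compound with a real number: in this assay compound 3 gives 39000 nM, which makes it the only point from which to reason.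

Compound 4 `CCCCCCc1ccc(-c2cn(Cc3cc(=O)oc4cc(O)ccc34)nn2)cc1` has not yet been measured. It differs from compound 3 by ethyl in place of hydrogen on a saturated chain carbon, four bonds along the chain from an aromatic carbon. Going by the values given here, no measured step resembles this change, so there is no direct guide to its size or direction; the one step that exists is unreadable and concerns a different group. The expectation therefore rests on compound 3 alone, and a small lengthening of a chain is expected to leave the value within or close to the usual scatter. Compound 4 is expected to give about 25000 nM in this assay, within a range from 8000 nM to 80000 nM. That estimate corresponds to an expected step of a 1.6-fold lower number from compound 3 to compound 4 (0.19 log units; within the scatter), not clearly beyond the scatter of repeated measurements.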

Compound 4, half-maximal inhibitory concentration: 8730 nM
Beside the measured number, compound 4's estimate is 2.9-fold (0.46 log units) above it; the measured number falls inside the stated range.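

For the compounds shown here, until now no step could be sized, and this assay now gives a first one at this position: ethyl in place of hydrogen on a saturated chain carbon, four bonds along the chain from an aromatic carbon, gives a 4.5-fold lower number from compound 3 to compound 4 (0.65 log units; beyond the scatter). The step is modest, but it shows that the number responds to a change this far along the chain, which compound 3 alone could not show. Compound 1 and compound 2 add no such reading, as each rests on a limit and not a number: the limit of > 100000 nM in this assay, at which 2 of the 4 values shown sit.

Going by these compounds, a single step makes no trend, so it remains open whether a longer chain, such as octyl, would lower the number further or reverse the change. Also open, on these data alone, is what an amine or a carboxylic acid on this chain would do to the number.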